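Fluoro for Methyl on the Central Ring: an Expected Step

The source may report more compounds than this note shows. Statements on the series, on what has been measured and on what is new or still open speak of the compounds shown alone.

Three analogues of one shared core have been measured in an assay on isolated protein for inhibition of Rho-associated protein kinase 2 (Homo sapiens), read by scintillation counting, radiometric assay and 33P incorporation, with a stated time of 40 min, in the presence of a further agent that is not named here; on this read-out higher numbers stand for weaker inhibition and lower numbers for stronger inhibition. Compound 1 `Cc1coc2cc(OCC(=O)Nc3cccc(NC(=O)c4ccc(N(C)C)cc4)c3)ccc2c1=O` gives 2150 nM. Compound 2 `CCOc1ccc(C(=O)Nc2cccc(NC(=O)COc3ccc4c(=O)ccoc4c3)c2)cc1` gives 9 nM. For compound 3 `Cc1cc(NC(=O)COc2ccc3c(=O)ccoc3c2)cc(NC(=O)c2ccc(N(C)C)cc2)c1` the assay reports only a limit, > 10000 nM, so compound 3 stands at the weak end of the set without a number of its own (the limit of > 10000 nM in this assay, at which 1 of the 3 values shown sits). Compound 4 `CN(C)c1ccc(C(=O)Nc2cc(F)cc(NC(=O)COc3ccc4c(=O)ccoc4c3)c2)cc1` has not yet been measured. It differs from compound 3 by a single exchange: fluoro in place of methyl on an aromatic carbon. Within the data shown here, no measured pair in this set differs in one place, so the size of this step cannot be read from the data and has to be expected rather than derived. With compound 3 sitting at the limit, any movement that the exchange brings can only show itself as a return into the measurable range, while a step that stays within the scatter would leave compound 4 at a limit as well. The step from compound 3 to compound 4 is expected to be an at least 2.5-fold lower number from compound 3 to compound 4 (0.39 log units; beyond the scatter). Compound 4 is expected to give about 4000 nM, within 1000 nM to 15000 nM, with a real chance that the assay again reports only a limit.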

Compound 4, half-maximal inhibitory concentration: 22 nM
Beside the measured number, compound 4's estimate is 180-fold (2.26 log units) above it; the whole stated range lies above it.
By their numbers in this assay, from the lowest: compound 2; then compound 4; then compound 1. At a limit, above all of these: compound 3.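

In this assay, among these compounds, fluoro in place of methyl on an aromatic carbon, meta to two large groups, gives an at least 450-fold lower number from compound 3 to compound 4 (2.65 log units; beyond the scatter), and this is the first step in the set that can be read between compounds differing in one place. It shows that this position is far from indifferent to what it carries: one heavy atom is exchanged for another, with no ring, hydrogen-bond donor, hydrogen-bond acceptor or net charge entering or leaving, and the compound moves from beyond the assay's range to a measured number. The size of the step is only a bound, because compound 3 has a limit and no number of its own: the limit of > 10000 nM in this assay, at which 1 of the 4 values shown sits.

The compounds shown leave open whether plain hydrogen on this carbon would read closer to the fluoro compound or the methyl compound, and how chloro, methoxy or an amine would fare at the same place. They also leave open whether the same exchange would bring a step of similar size with an ethoxy group in place of the dimethylamino group on the benzamide ring.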